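Restoring an aromatic ring at the chain end

A few compounds are considered here, and "the series" means these few. Any claim that something is new, unique, unknown or untested is made for them only; others in the source may bear on it.

Compound 2 `COC/C=C/c1ccc(CN(C(=O)C2CCCCC2)c2cccc(/C=C/C(=O)OC)c2)cc1` carries a 3-methoxyprop-1-en-1-yl group on its aromatic carbon, and in an assay on isolated protein with Bile acid receptor (Homo sapiens) as the target (on this read-out lower numbers stand for an effect already at smaller amounts and higher numbers for an effect only at larger amounts of compound), compound 2 gives 233 nM, the highest of the two numbers recorded so far. For the measured compounds named here, its nearest neighbour is compound 1 `COC(=O)/C=C/c1cccc(N(Cc2ccc(-c3c(OC)cccc3OC)cc2)C(=O)C2CCCCC2)c1`, which bears a 2,6-dimethoxyphenyl group in that position and in this assay gives 77 nM; the step of a 3.0-fold higher number from compound 1 to compound 2 (0.48 log units; beyond the scatter) is the only measured step available, and it shows that swapping the aromatic group for the short methoxy-bearing chain raised the number. Compound 3 `COC(=O)/C=C/c1cccc(N(Cc2ccc(/C=C/c3ccc(F)cc3)cc2)C(=O)C2CCCCC2)c1` differs from compound 2 by 4-fluorophenyl in place of methoxymethyl on a double-bonded chain carbon bound to a double-bonded chain carbon, so the chain now ends in an aromatic ring again. Because a 3.0-fold higher number from compound 1 to compound 2 (0.48 log units; beyond the scatter) pointed upward when an aromatic ring was removed from this region, a modest move in the opposite direction is expected when one is brought back, though the new ring is not the same one. For compound 3 the expected result is 110 nM, with a plausible range from 40 nM to 320 nM, meaning an expected step of a 2.1-fold lower number from compound 2 to compound 3 (0.33 log units; beyond the scatter).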

Compound 3, half-maximal effective concentration: 185 nM
Compound 3: the middle estimate sits 1.7-fold (0.23 log units) below what was measured; the measured number falls inside the stated range.
By their numbers in this assay, from the lowest: compound 1; then compounds 3 and 2 (each within the scatter of the next).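

In this assay, 4-fluorophenyl in place of methoxymethyl on a double-bonded chain carbon bound to a double-bonded chain carbon gives a 1.3-fold lower number from compound 2 to compound 3 (0.10 log units; within the scatter), so on this read-out the two chain ends cannot be told apart, even though only the entering group holds a ring. An aromatic ring at the end of the chain is therefore not enough on its own to match compound 1: 2-(4-fluorophenyl)ethenyl in place of 2,6-dimethoxyphenyl on an aromatic carbon gives a 2.4-fold higher number from compound 1 to compound 3 (0.38 log units; beyond the scatter), a gap close in size to the one seen with the ring-free chain of compound 2. No measurement is available that explains why the 2,6-dimethoxyphenyl group stands apart from both chains.

The three compounds leave open what sets that group apart, whether its two methoxy groups or its ring sitting directly on the aromatic carbon without the double-bonded chain. They also leave open how a chain end carrying an amine or a carboxylic acid would read in this assay at this position.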